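The source may hold more compounds than are shown below. What is called first, only, known or untested is meant among the compounds shown, and "the series" means these compounds.

Compound 2 `O=c1cc(-c2ccc(-c3ccccc3)cc2)oc2cc(OCCCCCCCCN3CCCC3)ccc12` gives 71.9% in an ADME assay on HepG2 cells (Homo sapiens) for cytotoxicity, read by MTT assay, with a stated time of 48 h, tested at 10 uM (on this read-out lower numbers stand for a weaker effect and higher numbers for a stronger effect at the one concentration tested), the higher of the two numbers in hand. Compound 1 `O=c1cc(-c2cccc(O)c2)oc2cc(OCCCCCCCCN3CCCC3)ccc12` gives 43.9% in this assay, and the step of a number 28 percentage points higher from compound 1 to compound 2 (beyond the scatter) is the only one measured so far. Compound 3 `COc1cc(-c2cc(=O)c3ccc(OCCCCCCCCN4CCCC4)cc3o2)cc(OC)c1OC` is the next to be measured in this assay; the change is 3,4,5-trimethoxyphenyl in place of 4-phenylphenyl on an aromatic carbon. Going by the values given here, no measured step covers this replacement directly. Among the compounds with values here, the step from compound 1 to compound 2 shows only that exchanging the group on this aromatic carbon moves the read-out by a modest amount, and that compound 2, carrying the 4-phenylphenyl, stands higher than its 3-hydroxyphenyl counterpart. Compound 3 carries neither of those groups, so the direction is uncertain, and a step of a number 21.9 percentage points lower from compound 2 to compound 3 (beyond the scatter) downward from compound 2 is expected. The estimate for compound 3 is 50%, with a range from 28% to 72% in this assay.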

Compound 3, a percentage reported as inhibition, at one concentration (the size of the read-out at that concentration, not a potency): 41.4%
Compound 3: middle estimate off by 8.6 percentage points, on the high side, and the stated range covers the measured number.
By their numbers in this assay, from the lowest: compounds 3 and 1 (each within the scatter of the next); then compound 2.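

In this assay, 3,4,5-trimethoxyphenyl in place of 4-phenylphenyl on this aromatic carbon gives a number 30.5 percentage points lower from compound 2 to compound 3 (beyond the scatter) and thus a large downward move, the first measured for this exchange. Against the 3-hydroxyphenyl group, the same substituent gives a number 2.5 percentage points lower from compound 1 to compound 3 (within the scatter) so these two groups are not separated on this read-out, and compound 2 alone stands apart among the three compounds. No supporting data bear on why the read-out moves at this position.

Whether the higher number of compound 2 goes with the second aromatic ring itself remains open, since only one group with two such rings is shown. Also open, as far as these compounds go, is how a naphthyl group, a pyridyl ring or a phenyl ring carrying a carboxylic acid or an amine would read on this aromatic carbon.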